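A few compounds are considered here, and "the series" means these few. Any claim that something is new, unique, unknown or untested is made for them only; others in the source may bear on it.

Measured so far:
compound 1 `CC(C)c1ccnc(C(=O)Nc2nn[nH]n2)c1` — 34%
compound 2 `COc1cccc(C(=O)Nc2nn[nH]n2)n1` — 36%

In a functional assay on the whole organism for inhibition, with Rattus norvegicus as the target, at a dose of 3 mg/kg by the oral route (a higher number here means a stronger effect of the compound at the dose given, a lower number a weaker effect), compound 1 gives 34%. Compound 2 gives 36% in this assay, and compound 1 stands within the scatter of compound 2, so no order between the two is claimed. Compound 3 `Cc1ccnc(C(=O)Nc2nn[nH]n2)c1` differs from compound 1 in one place: methyl in place of isopropyl on an aromatic carbon. Among the measured compounds shown here, no measured pair shows this change on its own, so its size cannot be read from the data. The expected step is a number 1 percentage points lower from compound 1 to compound 3 (within the scatter), within the scatter and in no set direction. Compound 3 is estimated at 33% in this assay, with a range from 15% to 50%.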

Compound 3, a percentage reported as inhibition, in the whole organism at one dose (the size of the read-out at that dose, not a potency): 42%
Compound 3: the middle estimate sits 9 percentage points below what was measured; the range from low to high includes it.
By their numbers in this assay, from the lowest: compounds 1, 2 and 3 (each within the scatter of the next).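

Methyl in place of isopropyl on the aromatic carbon opposite the ring nitrogen gives, in this assay, a number 8 percentage points higher from compound 1 to compound 3 (within the scatter). The two groups are therefore not told apart at this position at this dose, and the effect persists with either group. Nothing measured offers an explanation for this result.

On these data alone, it remains open whether an amine, a carboxylic acid or a longer chain at this carbon would separate from methyl and isopropyl. With one oral dose, potency also remains unresolved.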